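Swapping the Ring on the Thiocarbonyl of Compound 2

The compounds below may be only part of what the source reports. "The series", "measured", "known", "first", "only" and "open" are said of these compounds alone.

Compound 1 `N/C(=N\NC(=S)N1CCOCC1)c1ccc(F)cn1`: 66.4%
Compound 2 `N/C(=N\NC(=S)N1CCOCC1)c1ccccn1`: 19.3%
Compound 3 `Cc1ccnc(/C(N)=N/NC(=S)N2CCOCC2)c1`: 66.6%

In a functional assay on A-375 cells (Homo sapiens) for cytotoxicity, read by MTT assay, with a stated time of 72 h, tested at 3 uM (on this read-out lower numbers stand for less inhibition of growth and higher numbers for more inhibition of growth at the one concentration tested), compound 2 gives 19.3%, the lowest of the three numbers; compound 1 gives 66.4% and compound 3 gives 66.6%, both beyond the scatter above it. Compound 4 `N/C(=N\NC(=S)N1CCCC1)c1ccccn1` differs from compound 2 by pyrrolidin-1-yl in place of morpholin-4-yl on a thiocarbonyl carbon. The two measured steps, a number 47.1 percentage points lower from compound 1 to compound 2 (beyond the scatter) and a number 47.3 percentage points higher from compound 2 to compound 3 (beyond the scatter), both alter an aromatic carbon, not the thiocarbonyl carbon, so neither bears directly on this change; they only show that single changes in this series can move the read-out a great deal. With no direct guide, the number for compound 4 is expected to move by only a number 8.7 percentage points higher from compound 2 to compound 4 (within the scatter), within or barely beyond the scatter. The estimate for compound 4 is 28%, ranging from 8% to 58%.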

Compound 4, percent growth inhibition at one concentration: 80%
For compound 4 the middle estimate is 52 percentage points below the measured one, and the stated range ends below it.
By their numbers in this assay, from the lowest: compound 2; then compounds 1 and 3 (each within the scatter of the next); then compound 4.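

For the compounds shown here, the thiocarbonyl carbon proves to be a sensitive position: in this assay, pyrrolidin-1-yl in place of morpholin-4-yl gives a number 60.7 percentage points higher from compound 2 to compound 4 (beyond the scatter) and so moves the read-out strongly, which the earlier steps on the aromatic carbons could not show. This swap changes a six-membered ring with 2 hetero atoms to a five-membered ring with 1 hetero atom, so ring size and the loss of oxygen change together. Nothing available explains the rise.

Still open, as far as these compounds go, is whether piperidin-1-yl, a six-membered ring without oxygen, would behave like pyrrolidin-1-yl or like morpholin-4-yl. An open-chain dimethylamino group at this carbon is equally unresolved.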